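The compounds below may be only part of what the source reports. "The series", "measured", "known", "first", "only" and "open" are said of these compounds alone.

Compound 1 `CNC(=O)c1c(O)c2cccnc2n(-c2ccccc2)c1=O` and compound 2 `O=C(Nc1ccccc1)c1c(O)c2cccnc2n(-c2ccccc2)c1=O` share one core and differ only at the amide-type nitrogen, phenyl in place of methyl. In a functional assay on the whole organism for inhibition, with Rattus norvegicus as the target, read by cytopathic effect and paw edema, at a dose of 100 mg/kg by the oral route (a lower number here means less inhibition, a higher number more inhibition at the dose given (going by the name of the read-out)), compound 1 gives 21% and compound 2 gives -15%, the lower of the two numbers. Among the measured compounds shown here, the one measured step, a number 36 percentage points lower from compound 1 to compound 2 (beyond the scatter), is large. Compound 3 `Cc1ccc(NC(=O)c2c(O)c3cccnc3n(-c3ccccc3)c2=O)cc1` differs from compound 2 by methyl in place of hydrogen on an aromatic carbon, a change on the anilino phenyl rather than at the nitrogen, so that step gives no direct guidance. No shift beyond the scatter is expected; the estimated step is a number 5 percentage points higher from compound 2 to compound 3 (within the scatter). For compound 3 the expected value is -10%, within -35% to 18%.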

Compound 3, a percentage reported as inhibition, in the whole organism at one dose (the size of the read-out at that dose, not a potency): 2.2%
The estimate for compound 3 lay 12.2 percentage points below the measured number, and the stated range covers the measured number.
By their numbers in this assay, from the lowest: compound 2; then compound 3; then compound 1.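

In this assay, methyl on the anilino phenyl, para to a large group, shifts the read-out (a number 17.2 percentage points higher from compound 2 to compound 3 (beyond the scatter)), so this aromatic carbon also responds to change, not only the amide-type nitrogen. The 4-methylphenyl group still leaves the number short of the methyl amide (a number 18.8 percentage points lower from compound 1 to compound 3 (beyond the scatter)). Nothing available bears on the reason for either step.

Open: whether an amine or a carboxylic acid at the same ring carbon moves the number further, and how a longer chain such as propyl on the amide-type nitrogen compares with methyl.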